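Swapping iodine for bromine on a prenylated acylphloroglucinol analogue

The source may report more compounds than this note shows. Statements on the series, on what has been measured and on what is new or still open speak of the compounds shown alone.

Measured compounds:
Compound 1 `COC1=C(CC=C(C)C)C(=O)/C(=C(O)/C=C/c2ccccc2)C(=O)C1(CC=C(C)C)CC=C(C)C`: 8.9 uM
Compound 2 `CCCC1=C(OC)C(CCC)(CCC)C(=O)/C(=C(O)\C=C\c2ccc(I)cc2)C1=O`: 1.4 uM

Both compounds were tested in a functional assay on KBVIN cells (Homo sapiens) for antiproliferative activity, read by sulforhodamine B assay, with a stated time of 3 days; on this read-out higher numbers stand for an effect only at larger amounts of compound and lower numbers for an effect already at smaller amounts. Compound 1 gives 8.9 uM in this assay, while compound 2 gives 1.4 uM, the lower of the two numbers and clearly apart from compound 1. The two differ in several places at once, so nothing can be read about any single change from that pair.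

Compound 3 `CCCC1=C(OC)C(CCC)(CCC)C(=O)/C(=C(O)\C=C\c2ccc(Br)cc2)C1=O` has not been measured yet. It differs from compound 2 in one spot: bromo in place of iodo on an aromatic carbon. Put another way, the 4-iodophenyl group of compound 2 becomes a 4-bromophenyl group. One halogen replaces another of similar kind, so no large step is expected. The estimated step of a 1.4-fold higher number from compound 2 to compound 3 (0.15 log units; within the scatter) is within the scatter or a small loss. Compound 3 is therefore expected to give about 2 uM, between 0.9 uM and 4.5 uM.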

Compound 3, concentration for half-maximal effect: 1.8 uM
Beside the measured number, compound 3's estimate is 1.1-fold (0.05 log units) above it; the range from low to high includes it.
By their numbers in this assay, from the lowest: compounds 2 and 3 (each within the scatter of the next); then compound 1.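

Among these compounds, compound 2 and compound 3 form the first pair here that differs in one place only, so a single change can finally be read in this assay. Bromo in place of iodo at this spot on the aromatic ring gives a 1.3-fold higher number from compound 2 to compound 3 (0.11 log units; within the scatter), so this read-out does not tell these two halogens apart at this position. Nothing measured here offers an explanation for this result. The compounds shown leave open whether this position depends on having a halogen at all, as only iodo and bromo can be compared there. A smaller halogen such as fluoro, or a quite different group such as an amine or a carboxylic acid on the same aromatic carbon, could show how much change this position accepts.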